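Shifting the nitrile on the phenyl ring

This account rests on a few compounds, and the source may have more. Where it says the series, first, only, none or still open, it means among the compounds named here.

Compound 1 `COc1ccc(-n2cc(CN3C(=O)C[C@@H]4CC[C@@]3(C)C4(C)C)nn2)cc1`: 250 nM
Compound 2 `Cc1ccc(-n2cc(CN3C(=O)C[C@@H]4CC[C@@]3(C)C4(C)C)nn2)cc1`: 40 nM
Compound 3 `CC1(C)[C@H]2CC[C@]1(C)N(Cc1cn(-c3ccccc3C#N)nn1)C(=O)C2`: 110 nM

In a functional assay on OVCAR-3 cells (Homo sapiens) for inhibition, read by MTT assay, with a stated time of 24 h (a higher number here means a weaker inhibitor, a lower number a stronger inhibitor), compound 3 stands second highest of the three numbers, above compound 2 and below compound 1. Compound 4 `CC1(C)[C@H]2CC[C@]1(C)N(Cc1cn(-c3ccc(C#N)cc3)nn1)C(=O)C2` differs from compound 3 by 4-cyanophenyl in place of 2-cyanophenyl on an aromatic nitrogen. Among the compounds with values here, no measured step bears directly on this: a 6.3-fold lower number from compound 1 to compound 2 (0.80 log units; beyond the scatter) swaps methyl for methoxy, while a 2.3-fold lower number from compound 1 to compound 3 (0.36 log units; beyond the scatter) and a 2.8-fold higher number from compound 2 to compound 3 (0.44 log units; beyond the scatter) change both the group and its place at once. All three steps are modest, so a modest step at most is expected here, with no direction to guide it. Compound 4 is therefore expected to give 100 nM, between 40 nM and 250 nM. The expected step of a 1.1-fold lower number from compound 3 to compound 4 (0.04 log units; within the scatter) is within the scatter.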

Compound 4, half-maximal inhibitory concentration: 380 nM
The estimate for compound 4 lay 3.8-fold (0.58 log units) below the measured number, outside the stated range (above it).
By their numbers in this assay, from the lowest: compound 2; then compound 3; then compounds 1 and 4 (each within the scatter of the next).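

In this assay, moving the nitrile alone changes the result: 4-cyanophenyl in place of 2-cyanophenyl on the aromatic nitrogen gives a 3.5-fold higher number from compound 3 to compound 4 (0.54 log units; beyond the scatter) with the same atoms joined differently. Cyano in place of methyl on the aromatic carbon gives a 9.5-fold higher number from compound 2 to compound 4 (0.98 log units; beyond the scatter) and is the larger step. Cyano in place of methoxy gives a 1.5-fold higher number from compound 1 to compound 4 (0.18 log units; within the scatter) and so leaves these two compounds indistinguishable here. Nothing available explains these differences. Still open, going by these compounds, is how an amine or a carboxylic acid in place of the nitrile of compound 4 would read.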